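Tail amine swap: estimate for compound 3

This account rests on a few compounds, and the source may have more. Where it says the series, first, only, none or still open, it means among the compounds named here.

Measured compounds:
compound 1 `COc1cc2c(Oc3c(F)cc(NC(=O)NN4C(=O)CSC4c4c(F)cccc4F)cc3F)ccnc2cc1OCCCN1CCC(C)CC1`, 220 nM
compound 2 `CCN(CC)CCCOc1cc2nccc(Oc3c(F)cc(NC(=O)NN4C(=O)CSC4c4c(F)cccc4F)cc3F)c2cc1OC`, 91 nM

In a functional assay on HT-29 cells (Homo sapiens) for antiproliferative activity, read by MTT assay, with a stated time of 72 h (a higher number here means a weaker inhibitor, a lower number a stronger inhibitor), compound 2 stands lowest of the two numbers; its nearest neighbour is compound 1, and the step of a 2.4-fold lower number from compound 1 to compound 2 (0.38 log units; beyond the scatter) lies beyond the scatter. Compound 3 `CCN1CCN(CCCCOc2cc3nccc(Oc4c(F)cc(NC(=O)NN5C(=O)CSC5c5c(F)cccc5F)cc4F)c3cc2OC)CC1` is not yet measured. It differs from compound 2 by (4-ethylpiperazin-1-yl)methyl in place of diethylamino on a saturated chain carbon, three bonds along the chain from an oxygen on an aromatic ring. Among the measured compounds shown here, only one measured step bears on the tail amine, a 2.4-fold lower number from compound 1 to compound 2 (0.38 log units; beyond the scatter), where a ring amine gave way to diethylamino. For the measured compounds named here, compound 3 brings back a ring amine, set one carbon further out, so the expected direction is partly back toward compound 1, though the new ring is not the one in compound 1 and no measured pair shows (4-ethylpiperazin-1-yl)methyl at this place. A modest rise is therefore expected, a 1.6-fold higher number from compound 2 to compound 3 (0.22 log units; within the scatter), in this assay. For compound 3 the estimate is 150 nM, with a range from 60 nM to 400 nM.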

Compound 3, half-maximal inhibitory concentration: 830 nM
Beside the measured number, compound 3's estimate is 5.5-fold (0.74 log units) below it, and the stated range ends below it.
By their numbers in this assay, from the lowest: compound 2; then compound 1; then compound 3.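

In this assay, replacing 3-(diethylamino)propyl with 4-(4-ethylpiperazin-1-yl)butyl gives a 9.1-fold higher number from compound 2 to compound 3 (0.96 log units; beyond the scatter), so a return to a ring amine on this chain does not restore the level of the earlier ring amine. The new tail also separates from that earlier ring amine, with a 3.8-fold higher number from compound 1 to compound 3 (0.58 log units; beyond the scatter), so the series cannot be read as a simple contrast between ring amines and open-chain amines. No data at hand explain the shift.

The change in compound 3 alters both the amine and the chain, and the compounds shown do not separate these two contributions. A 3-(4-ethylpiperazin-1-yl)propyl tail or a 4-(diethylamino)butyl tail would separate them, while a morpholine on the same chain would test whether the ring amine's second nitrogen matters.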